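This account rests on a few compounds, and the source may have more. Where it says the series, first, only, none or still open, it means among the compounds named here.

Working notes on the series. The shared core is carried by compound 1 `N#Cc1c(-c2ccccc2)nc(SCC(=O)Nn2c(COc3ccc(Cl)cc3Cl)nc3ccccc3c2=O)[nH]c1=O`, compound 2 `O=C(CSc1nc(-c2ccccc2)c(C(=O)O)c(=O)[nH]1)Nn1c(COc2ccc(Cl)cc2Cl)nc2ccccc2c1=O` and compound 3 `Cn1c(SCC(=O)Nn2c(COc3ccc(Cl)cc3Cl)nc3ccccc3c2=O)nc(-c2ccccc2)c(C#N)c1=O`; compound 4 `N#Cc1c(-c2ccccc2)nc(SCC(=O)Nn2c(COc3ccc(Cl)cc3Cl)nc3ccccc3c2=O)n(Cc2ccccc2)c1=O` has not yet been measured. In a functional assay on the whole organism (strain albino) for inhibition, with Rattus norvegicus as the target, read by paw edema, with stated times of 1 h and 2 h, at a dose of 100 mg/kg by the oral route (a lower number here means less inhibition, a higher number more inhibition at the dose given (going by the name of the read-out)), compound 1 gives 86%. In this assay compound 2 gives 68.4%, and compound 3 gives 59.7%. Both measured steps run downward from compound 1: a number 17.6 percentage points lower from compound 1 to compound 2 (beyond the scatter), and a number 26.3 percentage points lower from compound 1 to compound 3 (beyond the scatter). Compound 3 therefore stands lowest of the three numbers; its gap to compound 2 lies within the scatter, its gap to compound 1 beyond it.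

The step to compound 4 is phenyl in place of hydrogen on a saturated chain carbon bound to an aromatic nitrogen. Going by the values given here, no measured step touches this saturated chain carbon. The nearest is a number 26.3 percentage points lower from compound 1 to compound 3 (beyond the scatter), which changed the same aromatic nitrogen from hydrogen to methyl and came down by a modest amount; a number 17.6 percentage points lower from compound 1 to compound 2 (beyond the scatter) sits at another place and serves only as a second example that single changes on the core have so far lowered the read-out modestly. With nothing measured for phenyl entering here, a step of at most modest size is expected, direction uncertain, a further lowering somewhat more likely than a rise; it is estimated as a number 7.7 percentage points lower from compound 3 to compound 4 (within the scatter). For compound 4 the expected value in this assay is 52%, with a range from 36% to 68%.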

Compound 4, a percentage reported as inhibition, in the whole organism at one dose (the size of the read-out at that dose, not a potency): 79%
For compound 4 the middle estimate is 27 percentage points below the measured one; measured number above the stated range.
By their numbers in this assay, from the lowest: compounds 3 and 2 (each within the scatter of the next); then compounds 4 and 1 (each within the scatter of the next).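

In this assay the aromatic nitrogen of the shared core does not respond to substitution in one direction: replacing methyl with benzyl there gives a number 19.3 percentage points higher from compound 3 to compound 4 (beyond the scatter) and so reverses much of the loss seen with methyl. Set against the unsubstituted nitrogen, benzyl gives a number 7 percentage points lower from compound 1 to compound 4 (within the scatter) and so shows that this position can carry a phenyl on the saturated chain carbon without a difference beyond the scatter, which the methyl compound alone gave no sign of. Nothing on hand offers an explanation for the contrast between methyl and benzyl at this nitrogen.

The compounds shown leave open how an ethyl group, a longer alkyl chain or a phenethyl group on this nitrogen would read, and so whether the phenyl ring itself or simply a longer substituent accounts for the contrast. Also open, as far as these compounds go, is whether benzyl on this nitrogen would read the same with the carboxy group of compound 2 in place of the nitrile.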